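The compounds below may be only part of what the source reports. "The series", "measured", "known", "first", "only" and "open" are said of these compounds alone.

Measured so far: compound 1 `COc1cc(-c2cc(/C=C/C(=O)c3ccc(N)cc3)[nH]n2)cc(OC)c1OC`, 4020 nM; compound 2 `COc1ccc(-c2cc(/C=C/C(=O)c3ccc(OC)c(OC)c3)[nH]n2)cc1`, 3650 nM, both in a functional assay on UACC-257 cells (Homo sapiens) for inhibition, read by sulforhodamine B assay, with a stated time of 48 h; a lower number here means a stronger inhibitor of growth, a higher number a weaker inhibitor of growth.

Compound 1 stands at the top of the two numbers shown in this assay, yet compound 2 lies within the scatter of it, so the two are taken as equivalent. Compound 3 `COc1cc(-c2cc(/C=C/C(=O)c3ccc(Cl)c(Cl)c3)[nH]n2)cc(OC)c1OC` has not been measured. From compound 1 it differs by 3,4-dichlorophenyl in place of 4-aminophenyl on a carbonyl carbon. Within the data shown here, no step between measured compounds exists to guide the change, so the step of a 1.0-fold lower number from compound 1 to compound 3 (0.00 log units; within the scatter) is expected to stay within the scatter, without a clear direction. Compound 3 is estimated at 4000 nM, with a range from 1500 nM to 11000 nM.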

Compound 3, concentration for total growth inhibition: 74000 nM
Beside the measured number, compound 3's estimate is 19-fold (1.27 log units) below it; the whole stated range lies below it.
By their numbers in this assay, from the lowest: compounds 2 and 1 (each within the scatter of the next); then compound 3.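

Among these compounds, the group on the carbonyl carbon clearly matters in this assay: 3,4-dichlorophenyl in place of 4-aminophenyl gives an 18-fold higher number from compound 1 to compound 3 (1.27 log units; beyond the scatter) and weakens growth inhibition, a result the earlier compounds, with no step between them, could not show. The entering ring carries no hydrogen-bond donor or acceptor, whereas the leaving one carries one of each, but this count is only a difference between the structures. No measurement here accounts for the loss.

Still open, as far as these compounds go, is whether the loss follows from removing the amine or from adding the two chlorines. A 4-hydroxyphenyl or a 4-chlorophenyl on the same carbonyl carbon would bear on that question.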